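Working notes: a carbonyl enters the series

This account rests on a few compounds, and the source may have more. Where it says the series, first, only, none or still open, it means among the compounds named here.

In a physicochemical assay for solubility, read by spectrophotometry, measured as thermodynamic solubility, with a stated time of 24 h, at pH 6.8 (on this read-out lower numbers stand for lower solubility and higher numbers for higher solubility), compound 1 `CC(C)(Oc1ccc(CCOc2ccc(/N=N/c3ccccc3)cc2)cc1)C(=O)O` gives 14 ug/mL and compound 2 `CC(C)(Oc1ccc(CCCOc2ccc(/C=C/c3ccccc3)cc2)cc1)C(=O)O` gives 27.9 ug/mL. These two values lie within the scatter of each other, so compound 2 holds no distinct rank. Compound 3 `CC(C)(Oc1ccc(CCCOc2ccc(C(=O)/C=C/c3ccccc3)cc2)cc1)C(=O)O` carries (2-phenylethenyl)carbonyl in place of 2-phenylethenyl on an aromatic carbon, para to a large group: (2-phenylethenyl)carbonyl in place of 2-phenylethenyl on an aromatic carbon. Going by the values given here, no measured pair isolates this change, so the expectation is weakly grounded. The expected step is a 1.3-fold lower number from compound 2 to compound 3 (0.10 log units; within the scatter), an estimate that stays within the scatter. For compound 3 the estimated value in this assay is 22 ug/mL, with an expected range of 8 ug/mL to 60 ug/mL.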

Compound 3, solubility: 16 ug/mL
Compound 3: the middle estimate sits 1.4-fold (0.14 log units) above what was measured; measured number inside the range.
By their numbers in this assay, from the lowest: compounds 1, 3 and 2 (each within the scatter of the next).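

The exchange of 2-phenylethenyl for (2-phenylethenyl)carbonyl on an aromatic carbon, para to a large group, gives the first step readable at this position: a 1.7-fold lower number from compound 2 to compound 3 (0.24 log units; within the scatter). The larger group, with its carbonyl and one hydrogen-bond acceptor, therefore produces no step beyond the scatter in this assay. No measurement bears on the reason for this result. On these data alone, it remains open whether an amine or a carboxylic acid at this position would give a step beyond the scatter, and whether the same exchange would read alike with a longer chain elsewhere in the shared core.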